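From 3,4-dichlorophenyl to 4-methoxyphenyl: working notes

The source may report more compounds than this note shows. Statements on the series, on what has been measured and on what is new or still open speak of the compounds shown alone.

In a physicochemical assay for solubility, in phosphate buffer, at pH 7.4 (on this read-out higher numbers stand for higher solubility and lower numbers for lower solubility), compound 1 (`CCOC(=O)c1c(-c2ccccc2)[nH]c2cc(OC)ccc2c1=O`) reads > 100000 nM, which is a limit of the assay and not a number. Compound 2 (`CCOC(=O)c1c(-c2ccc(C(C)(C)C)cc2)[nH]c2cc(OC)ccc2c1=O`) gives 2000 nM, and compound 3 (`CCOC(=O)c1c(-c2ccc(Cl)c(Cl)c2)[nH]c2cc(OC)ccc2c1=O`) gives 17000 nM, the higher of the two actual numbers in the series.

Compound 4 (`CCOC(=O)c1c(-c2ccc(OC)cc2)[nH]c2cc(OC)ccc2c1=O`) has 4-methoxyphenyl in place of 3,4-dichlorophenyl on an aromatic carbon, next to the ring nitrogen and ortho to an ethoxycarbonyl group: 4-methoxyphenyl in place of 3,4-dichlorophenyl on an aromatic carbon.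

Among the measured compounds shown here, two measured steps bear on this change: the large at least 50-fold lower number from compound 1 to compound 2 (1.69 log units; beyond the scatter) and the at least modest an at least 5.8-fold lower number from compound 1 to compound 3 (0.76 log units; beyond the scatter). For the measured compounds named here, both lead away from the unsubstituted phenyl of compound 1 towards lower numbers, but no measured compound carries a methoxy group, so the read-across is loose. Compound 4 is therefore expected to fall between compound 3 and the limit of compound 1. A modest upward move is expected in this assay, a 2.4-fold higher number from compound 3 to compound 4 (0.37 log units; beyond the scatter). The estimate for compound 4 is 40000 nM, with an expected range from 15000 nM to 100000 nM.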

Compound 4, solubility: 8000 nM
Compound 4: the middle estimate sits 5.0-fold (0.70 log units) above what was measured; measured number below the stated range.
By their numbers in this assay, from the lowest: compound 2; then compound 4; then compound 3. At a limit, above all of these: compound 1.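

At this position, next to the ring nitrogen, a single methoxy in place of hydrogen already gives a clear change in this assay, an at least 12-fold lower number from compound 1 to compound 4 (1.09 log units; beyond the scatter), but that step is only a bound since compound 1 stands at a limit: the limit of > 100000 nM in this assay, at which 1 of the 4 values shown sits.

The entering 4-methoxyphenyl brings a hydrogen-bond acceptor that 3,4-dichlorophenyl lacks, yet the result is a 2.1-fold lower number from compound 3 to compound 4 (0.33 log units; beyond the scatter). Methoxy in place of tert-butyl gives a 4.0-fold higher number from compound 2 to compound 4 (0.60 log units; beyond the scatter), so the three substituted phenyl groups also differ from one another, not only from the unsubstituted phenyl.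

Going by these compounds, whether an amine on this phenyl, or a pyridine in its place, would follow the same order stays open. Also open, on these data alone, is how the numbers would shift with a carboxylic acid in place of the ethoxycarbonyl group.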